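Trading the imidazole of compound 1 for dimethylamino

The compounds below may be only part of what the source reports. "The series", "measured", "known", "first", "only" and "open" are said of these compounds alone.

Compound 1 `O=C1c2c[n+]([O-])c3ccccc3c2C(=O)c2c1c1ccccc1n2CCCCn1ccnc1` gives 210 nM in a functional assay on MDA-MB-231 cells (Homo sapiens) for cytotoxicity, read by MTT assay, with a stated time of 72 h (on this read-out higher numbers stand for weaker inhibition and lower numbers for stronger inhibition), the lowest number among the three compounds measured here. Compound 2 `O=C1c2c[n+]([O-])c3ccccc3c2C(=O)c2c1c1ccccc1n2Cc1cn(CC(O)CO)nn1` gives 1290 nM and compound 3 `CN1CCN(CCCCCCn2c3c(c4ccccc42)C(=O)c2c[n+]([O-])c4ccccc4c2C3=O)CC1` gives 2400 nM in this assay. Compound 4 `CN(C)CCCCn1c2c(c3ccccc31)C(=O)c1c[n+]([O-])c3ccccc3c1C2=O` differs from compound 1 by dimethylamino in place of 1H-imidazol-1-yl on a saturated chain carbon, four bonds along the chain from an aromatic nitrogen. The closest measured comparison is an 11-fold higher number from compound 1 to compound 3 (1.06 log units; beyond the scatter), where 2-(4-methylpiperazin-1-yl)ethyl replaces the 1H-imidazol-1-yl at the same place; the other change from compound 1, a 6.1-fold higher number from compound 1 to compound 2 (0.79 log units; beyond the scatter), also weakened inhibition. Since both measured departures from compound 1 raised the number, a modest rise is expected for compound 4, as a 2.6-fold higher number from compound 1 to compound 4 (0.42 log units; beyond the scatter). Compound 4 is therefore estimated at 550 nM in this assay, within 180 nM to 1700 nM.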

Compound 4, half-maximal inhibitory concentration: 350 nM
Compound 4: the middle estimate sits 1.6-fold (0.20 log units) above what was measured; the range from low to high includes it.
By their numbers in this assay, from the lowest: compounds 1 and 4 (each within the scatter of the next); then compounds 2 and 3 (each within the scatter of the next).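

Replacing the imidazole ring with ring-free dimethylamino gives a 1.7-fold higher number from compound 1 to compound 4 (0.22 log units; within the scatter) and so leaves the number level, which shows that an aromatic ring at this chain end is not required here. Dimethylamino also stands clear of the other two, with a 6.9-fold lower number from compound 3 to compound 4 (0.84 log units; beyond the scatter) and a 3.7-fold lower number from compound 2 to compound 4 (0.57 log units; beyond the scatter) in this comparison, so the loss seen in compound 2 and compound 3 does not follow simply from giving up the imidazole. Nothing measured here explains these steps.

From the compounds shown here alone, whether a smaller amine such as methylamino, or a carboxylic acid, would hold this level at the chain end remains open. So does the effect of a shorter or longer chain carrying dimethylamino.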